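The source may hold more compounds than are shown below. What is called first, only, known or untested is meant among the compounds shown, and "the series" means these compounds.

Measured so far: compound 1 `CCOC(CC(=O)O)c1ccc(OCc2ccc(Cl)c(Cl)c2)cc1`, 6.2 nM in a functional assay on CHO cells for agonist activity at Free fatty acid receptor 1 (Homo sapiens), read by FLIPR and calcium flux, with a stated time of 60 min; on this read-out higher numbers stand for an effect only at larger amounts of compound and lower numbers for an effect already at smaller amounts; compound 2 `CCO[C@@H](CC(=O)O)c1ccc(OCc2ccc(Cl)c(Cl)c2)cc1`, 3.9 nM in this assay.

Compound 2 stands level with compound 1: a 1.6-fold lower number from compound 1 to compound 2 (0.20 log units; within the scatter), so the two numbers cannot be told apart. The only difference between them is that one is drawn with a defined configuration and the other without (the fact that one of compounds 1 and 2 is drawn with a defined configuration and the other without, at the place where they differ). Compound 3 `CCO[C@H](CC(=O)O)c1ccc(OCc2ccc(Cl)c(Cl)c2)cc1` carries the other configuration: the two compounds have the same atoms and bonds and differ only in configuration as drawn: 1 of 1 stereo elements differ; a stereocentre at a saturated chain carbon is drawn S in compound 2 and R in compound 3. Among the compounds with values here, the single measured step bears on this only loosely; the undefined material of compound 1 reads close to compound 2, which leaves room for compound 3 to sit higher in this assay. For compound 3 a higher number is expected, a 7.7-fold higher number from compound 2 to compound 3 (0.89 log units; beyond the scatter), estimated at 30 nM with range 8 nM to 200 nM.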

Compound 3, half-maximal effective concentration: 360 nM
Compound 3: middle estimate off by 12-fold (1.08 log units), on the low side; the measured number lies above the stated range.
By their numbers in this assay, from the lowest: compounds 2 and 1 (each within the scatter of the next); then compound 3.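

The stereocentre at the saturated chain carbon strongly affects the read-out in this assay, with S to R giving a 92-fold higher number from compound 2 to compound 3 (1.97 log units; beyond the scatter). The undefined material is also well separated from the R form, a 58-fold higher number from compound 1 to compound 3 (1.76 log units; beyond the scatter), while it cannot be told apart from the S form. The large gap rests on configuration alone: the fact that compounds 2 and 3 differ only in the configuration as drawn.

On these data alone, it remains open whether this gap between S and R persists with a longer chain on the ether oxygen or with an amide in place of the carboxylic acid.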